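Replacing (4-methylphenyl)sulfonyl with Phenyl in Compound 3

The source may report more compounds than this note shows. Statements on the series, on what has been measured and on what is new or still open speak of the compounds shown alone.

Of the compounds shown here, three that share one core have been measured in a functional assay on HepG2 cells (Homo sapiens) for cytotoxicity, read by sulforhodamine B assay, with a stated time of 24 h; a lower number here means a stronger inhibitor, a higher number a weaker inhibitor. Compound 1 `N#CCC(=O)N/N=C1\C(=O)Nc2ccc(S(=O)(=O)N3CCOCC3)cc21` gives 7530 nM, compound 2 `COc1ccc(-c2c(C#N)c(N)n(/N=C3\C(=O)Nc4ccc(S(=O)(=O)N5CCOCC5)cc43)c(=O)c2C#N)cc1` gives 15000 nM, and compound 3 `Cc1ccc(S(=O)(=O)N/N=C2\C(=O)Nc3ccc(S(=O)(=O)N4CCOCC4)cc32)cc1` gives 24700 nM. Compound 2 and compound 3 lie within the usual scatter of each other, so they cannot be ranked. Compound 3 does stand clearly apart from compound 1, which has the lower number.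

Compound 4 `O=C1Nc2ccc(S(=O)(=O)N3CCOCC3)cc2/C1=N/Nc1ccccc1` has not yet been measured. It carries phenyl in place of (4-methylphenyl)sulfonyl on an amine nitrogen. Going by the values given here, only one measured step bears on this change, as it also involves (4-methylphenyl)sulfonyl on an amine nitrogen. That modest step is a 3.3-fold higher number from compound 1 to compound 3 (0.52 log units; beyond the scatter), with (4-methylphenyl)sulfonyl in place of (cyanomethyl)carbonyl. Among the compounds with values here, no measured compound shows what phenyl does here, so this single step is only a weak guide. Losing the (4-methylphenyl)sulfonyl may undo part of that rise, so a small move toward a lower number is expected, probably not beyond the scatter. The expected step is a 1.8-fold lower number from compound 3 to compound 4 (0.25 log units; within the scatter). For compound 4 the estimated value in this assay is 14000 nM, within an expected range of 5000 nM to 40000 nM.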

Compound 4, half-maximal inhibitory concentration: 15600 nM
Compound 4: the middle estimate sits 1.1-fold (0.05 log units) below what was measured; the range from low to high includes it.
By their numbers in this assay, from the lowest: compounds 1, 2, 4 and 3 (each within the scatter of the next, the first and the last beyond it).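

In this assay, removing the sulfonyl link and the methyl group leaves a phenyl on the same amine nitrogen, and the result is a 1.6-fold lower number from compound 3 to compound 4 (0.20 log units; within the scatter). The 10 heavy atoms of (4-methylphenyl)sulfonyl, with their 2 hydrogen-bond acceptors, can therefore give way to the 6 carbon atoms of phenyl without a readable difference, so this pair does not show that the sulfonyl part matters for the number. The other comparison is a 2.1-fold higher number from compound 1 to compound 4 (0.32 log units; beyond the scatter), which sits alongside a 3.3-fold higher number from compound 1 to compound 3 (0.52 log units; beyond the scatter) and shows that both groups with a six-membered aromatic ring stand apart from (cyanomethyl)carbonyl at this nitrogen, although nothing available here explains that difference.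

The compounds shown leave open whether the aromatic ring itself is what separates compound 3 and compound 4 from compound 1, a question that a cyclohexyl or a plain acetyl on the same amine nitrogen could help to answer. As far as these compounds go, it also remains open whether a carboxylic acid or an amine on the phenyl of compound 4 would move the number beyond the scatter in either direction.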